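Swapping phenyl for thiazolyloxy in an M5 modulator series

This account rests on a few compounds, and the source may have more. Where it says the series, first, only, none or still open, it means among the compounds named here.

Measured compounds:
- compound 1 `O=C1C(=O)N(Cc2ccc(-c3ccncc3)cn2)c2ccc(OC(F)(F)F)cc21`: "not determined" (no result reported)
- compound 2 `O=C1C(=O)N(Cc2ccc(-c3ccccc3)cc2)c2ccc(OC(F)(F)F)cc21`: < 60%
- compound 3 `O=C1C(=O)N(Cc2ccc(-c3ccccc3)cn2)c2ccc(OC(F)(F)F)cc21`: 47%

The three measured compounds share one core and differ in the aryl group attached through the methylene arm. In a functional assay on CHO cells for positive allosteric modulation of muscarinic acetylcholine receptor M5 (Homo sapiens), read by FLIPR and calcium flux, with a stated time of 1 h (on this read-out lower numbers stand for smaller maximal responses and higher numbers for larger maximal responses), compound 3 gives 47%. For compound 2 the assay reports only a limit, < 60%, so no single number places it on the scale. Compound 1 has no result at all. Among the compounds with values here, compound 2 therefore stands on a limit, with one further entry beside it that also carries no single number, and there is no step between measured compounds from which a trend could be read; the one anchor is the limit of < 60% in this assay, at which 1 of the 3 values shown sits.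

Compound 4 `O=C1C(=O)N(Cc2ccc(Oc3nccs3)cc2)c2ccc(OC(F)(F)F)cc21` differs from compound 2 by (1,3-thiazol-2-yl)oxy in place of phenyl on an aromatic carbon. Within the data shown here, no measured pair shows what such an exchange does to the maximal response here. Compound 3 sits at 47%. Compound 2 stands only at a limit. Against that background the expected step that the limit leaves unreadable from compound 2 to compound 4 is one of no change beyond the scatter. Compound 4 is estimated to reach 45% in this assay, within a range from 20% to 70%.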

Compound 4, largest response reached (Emax), in percent of the reference or control that the assay uses: 58%
The estimate for compound 4 lay 13 percentage points below the measured number, and the stated range covers the measured number.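

Within the data shown here, no step from compound 2 to compound 4 can be read in this assay, because the result for compound 2 is a limit and not a number: the limit of < 60% in this assay, at which 1 of the 4 values shown sits. The compounds shown leave open whether (1,3-thiazol-2-yl)oxy in place of phenyl raises, lowers or leaves unchanged the largest response.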